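The compounds below may be only part of what the source reports. "The series", "measured", "known", "first", "only" and "open" are said of these compounds alone.

Compound 1 `CCCCC(=O)Nc1cc(-c2ccccc2)nc(-c2ccccc2)n1` carries a butylcarbonyl amide on a diphenyl-substituted core; in an assay on CHO cells for displacement of a labelled ligand from adenosine receptor A1 (Homo sapiens) (a higher number here means a weaker inhibitor, a lower number a stronger inhibitor), compound 1 gives 109 nM. Compound 2 `CC(C)(C)C(=O)Nc1cc(-c2ccccc2)nc(-c2ccccc2)n1` differs from it by one change, (tert-butyl in place of butyl on a carbonyl carbon), and in this assay compound 2 gives 27.7 nM, so that a 3.9-fold lower number from compound 1 to compound 2 (0.59 log units; beyond the scatter). Compound 3 `CCCCC(=O)Nc1nc(-c2ccccc2)cc(-c2ccccc2)n1` keeps the butylcarbonyl amide but sits on a core that is joined differently; the difference between the two cores is not broken down here. In this assay compound 3 gives 27.6 nM, a number that lies within the scatter of the value of compound 2. Compound 4 `CC(C)(C)C(=O)Nc1nc(-c2ccccc2)cc(-c2ccccc2)n1` is not yet measured; it arises from compound 3 by the same change, (tert-butyl in place of butyl on a carbonyl carbon). On these data alone, for compound 4 a step of a 2.8-fold lower number from compound 3 to compound 4 (0.44 log units; beyond the scatter) is expected, because the same change gave a 3.9-fold lower number from compound 1 to compound 2 (0.59 log units; beyond the scatter), though its carry-over to the other core is untested. Compound 4 is therefore estimated at 10 nM, between 3.5 nM and 35 nM.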

Compound 4, inhibition constant: 224 nM
Compound 4: the middle estimate sits 22-fold (1.35 log units) below what was measured, and the stated range ends below it.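

In this assay, tert-butyl in place of butyl on the carbonyl carbon gives an 8.1-fold higher number from compound 3 to compound 4 (0.91 log units; beyond the scatter) and so runs opposite to the step on the core of compound 1. The change therefore does not carry over between these two cores, in direction or in size: the same change on two cores in this assay, a 3.9-fold lower number (0.59 log units; beyond the scatter) from compound 1 to compound 2 and an 8.1-fold higher number (0.91 log units; beyond the scatter) from compound 3 to compound 4, 32-fold (1.50 log units) apart, beyond the scatter of two such steps. Among these compounds, this shows that a step read on one core cannot be transferred to the other, but with only two pairs it does not show which difference between the cores matters or how the change would behave on any further core.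

The compounds shown leave open whether other groups on the carbonyl carbon, such as a cyclopentyl ring or a longer chain, would split the same way between the two cores. They also leave open whether a methoxy group on either phenyl ring would alter this reversal.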